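The source may report more compounds than this note shows. Statements on the series, on what has been measured and on what is new or still open speak of the compounds shown alone.

Compound 1, `Cc1ccc(Cn2cc(CSC(=S)N3CCN(C(=O)OC(C)(C)C)CC3)nn2)cc1`, gives 17300 nM in a functional assay on PC-3 cells (Homo sapiens) for inhibition, read by MTT assay, with a stated time of 72 h; a higher number here means a weaker inhibitor, a lower number a stronger inhibitor.
Compound 2, `S=C(SCc1cn(Cc2ccccc2Cl)nn1)N1CCNCC1`, is recorded as "not determined" (no result reported) in this assay.

Compound 2 therefore stands nowhere on the scale of this assay: no result is reported for it, so there is no value to compare with compound 1, and nothing can be said about whether it is weaker or stronger. The only measured anchor in the whole set is compound 1, which is a weak inhibitor.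

The step from compound 2 leads to compound 3, `Cc1ccc(Cn2cc(CSC(=S)N3CCNCC3)nn2)cc1`. The change is 4-methylphenyl in place of 2-chlorophenyl on a saturated chain carbon bound to an aromatic nitrogen. Compound 3 thus keeps the free piperazine of compound 2 and takes over the 4-methylphenyl that compound 1 carries. Going by the values given here, no step between two measured compounds is available to say how large a shift this change produces or in which direction, so the expectation can only be that the number stays in the weak range and that any shift is not clearly beyond the usual scatter.

Compound 3 is expected to give about 15000 nM, with a range from 4000 nM to 60000 nM, because compound 1 gives 17300 nM.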

Compound 3, half-maximal inhibitory concentration: 19800 nM
Compound 3: middle estimate off by 1.3-fold (0.12 log units), on the low side, within the range that was stated.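

In this assay, going by these compounds alone, hydrogen in place of tert-butoxycarbonyl on an amine nitrogen in a ring gives a 1.1-fold higher number from compound 1 to compound 3 (0.06 log units; within the scatter), the first step in this set that can be read. With the 4-methylphenyl held constant, the free piperazine of compound 3 and the capped piperazine of compound 1 therefore cannot be told apart in this assay, and both stay in the weak range; the step from compound 2 to compound 3, which swaps 2-chlorophenyl for 4-methylphenyl, cannot be read, as compound 2 has no value. Nothing shown explains why removing the tert-butoxycarbonyl leaves the reading within the scatter.

From the compounds shown here alone, it remains open whether other groups on that ring nitrogen, such as an acetyl or a longer alkyl chain, would also leave the number where it is, or whether this nitrogen simply has little bearing on the reading. The effect of the group on the saturated chain carbon bound to an aromatic nitrogen is also unknown, for instance of a plain phenyl or a 4-methoxyphenyl in place of 4-methylphenyl.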